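The compounds below may be only part of what the source reports. "The series", "measured", "known", "first", "only" and "open" are said of these compounds alone.

Compound 1 `CCC(CC)Oc1ccc(CN[C@H]2CC(C(=O)O)=C[C@@H](OC(CC)CC)[C@@H]2NC(C)=O)cc1` carries the shared core of the series. In an ADME assay on cells (Fibroblast, Gallus gallus) for cytotoxicity, read by CCK-8 assay, with a stated time of 48 h (on this read-out lower numbers stand for higher toxicity in this test and higher numbers for lower toxicity in this test), compound 1 gives > 200000 nM, which is a limit of the assay and not a number. Compound 2 `CCC(CC)O[C@@H]1C=C(C(=O)O)C[C@H](NCc2cccc(SC3CCCC3)c2)[C@H]1NC(C)=O` gives > 200000 nM in this assay, again a limit. Compound 3 `CCC(CC)O[C@@H]1C=C(C(=O)O)C[C@H](NCc2cccc(-c3ccc(SC)cc3)c2)[C@H]1NC(C)=O` gives > 200000 nM in this assay, also a limit. The step that the two limits leave unreadable from compound 2 to compound 3 stays unreadable because the limit of > 200000 nM in this assay, at which 3 of the 3 values shown sit, holds for both ends. Compound 1 thus stands only at a limit, as do the other two values. Compound 4 `CCC(CC)O[C@@H]1C=C(C(=O)O)C[C@H](NCc2ccc(-c3csc4ccccc34)cc2)[C@H]1NC(C)=O` differs from compound 1 by 1-benzothiophen-3-yl in place of (pentan-3-yl)oxy on an aromatic carbon. For the measured compounds named here, no measured step bears on this change, and the three limits give no direction beyond the scatter. Compound 4 is expected to sit at 250000 nM, between 100000 nM and 600000 nM. The estimated step that the limit leaves unreadable from compound 1 to compound 4 is expected to stay within the scatter.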

Compound 4, half-maximal cytotoxic concentration: > 200000 nM
Compound 4: a limit, no number (the forecaster's own chance of this, stated with the estimate: 75%); the middle value is on the limit's open side.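

No step can be read from compound 1 to compound 4, as both stand only at a limit: the limit of > 200000 nM in this assay, at which 4 of the 4 values shown sit.

The compounds shown leave open whether any change on the shared core alters the read-out in this assay.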